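The compounds below may be only part of what the source reports. "The series", "measured", "known", "first", "only" and "open" are said of these compounds alone.

Working notes on the series.

Two compounds have numbers in a physicochemical assay for solubility, at pH 2; a lower number here means a less soluble compound, a higher number a more soluble compound. Compound 1, `CNc1nc(NCCCN(C)C)c2sc(-c3ccc(-n4cccn4)cc3)cc2n1`, gives 217 ug/mL in this assay. Compound 2, `CNc1nc(NCCCN(C)C)c2oc(-c3ccccc3)cc2n1`, gives 214 ug/mL in this assay. Within the data shown here, compound 1 holds the higher of the two numbers, but the gap to compound 2 lies within the scatter, so the two compounds read as alike in this assay, and no step between measured compounds is available.

Compound 3, `CNc1nc(NCCCN(C)C)c2sc(-c3ccc(N)cc3)cc2n1`, is not yet measured. It differs from compound 1 in one place: amino in place of 1H-pyrazol-1-yl on an aromatic carbon. The replacement puts amino in place of 1H-pyrazol-1-yl on an aromatic carbon, para to a large group.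

Among the measured compounds shown here, with no measured step to lean on, the expectation rests on the two numbers already in hand, which sit close together. For compound 3 the expected step from compound 1 is a 1.4-fold higher number from compound 1 to compound 3 (0.14 log units; within the scatter), a modest rise that may still fall inside the scatter. The estimate for compound 3 in this assay is 300 ug/mL, with a range from 130 ug/mL to 700 ug/mL.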

Compound 3, solubility: > 100 ug/mL
Compound 3: no number, only a limit; the forecaster's own chance of this, stated with the estimate: 5%; the middle value does not contradict the limit.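

In this assay compound 3 gives > 100 ug/mL, which is a limit and not a number. Among these compounds, no step from compound 1 to compound 3 can therefore be read. The compounds shown leave open how large a change in this assay, and in which direction, comes with amino in place of 1H-pyrazol-1-yl.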